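This account rests on a few compounds, and the source may have more. Where it says the series, first, only, none or still open, it means among the compounds named here.

Within the data shown here, in a functional assay on PC-3 cells (Homo sapiens) for antiproliferative activity, read by MTT assay, tested at 5 uM (on this read-out lower numbers stand for a weaker effect and higher numbers for a stronger effect at the one concentration tested), compound 2 `COc1cc(C2=NN(C(C)=O)C(c3ccc(Cl)c([N+](=O)[O-])c3)O2)cc(OC)c1OC` gives 61.4%, the highest of the two numbers known, while compound 1 `COc1ccc(OC)c(C2OC(c3cc(OC)c(OC)c(OC)c3)=NN2C(C)=O)c1` gives 43.2%. Among the measured compounds shown here, the only step measured so far, a number 18.2 percentage points higher from compound 1 to compound 2 (beyond the scatter), came from exchanging the ring on the saturated ring carbon, so that position clearly matters. Compound 3 `COc1cc(C2=NN(C(C)=O)C(c3cccc(C(F)(F)F)c3)O2)cc(OC)c1OC` differs from compound 2 by 3-(trifluoromethyl)phenyl in place of 4-chloro-3-nitrophenyl on a saturated ring carbon. For the measured compounds named here, no step with this new ring has been measured, so the size of its effect is uncertain, and a modest drop or no change seems most likely. Compound 3 is therefore expected to give 50%, between 30% and 70%, an expected step of a number 11.4 percentage points lower from compound 2 to compound 3 (beyond the scatter).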

Compound 3, a percentage reported as inhibition, at one concentration (the size of the read-out at that concentration, not a potency): 43.6%
Compound 3: the middle estimate sits 6.4 percentage points above what was measured, within the range that was stated.
By their numbers in this assay, from the lowest: compounds 1 and 3 (each within the scatter of the next); then compound 2.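

A second substituted phenyl ring brings a number 17.8 percentage points lower from compound 2 to compound 3 (beyond the scatter), so having a substituted phenyl ring on the saturated ring carbon does not by itself give the number seen with 4-chloro-3-nitrophenyl. Changing the other ring gives a number 0.4 percentage points higher from compound 1 to compound 3 (within the scatter), so 3-(trifluoromethyl)phenyl and 2,5-dimethoxyphenyl cannot be told apart here. No data are available to explain these differences. The compounds shown leave open whether the chlorine, the nitro group or the two together go with the higher number in compound 2. They also leave open how a phenyl ring bearing an amine or a carboxylic acid would read.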